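The source may hold more compounds than are shown below. What is called first, only, known or untested is meant among the compounds shown, and "the series" means these compounds.

In a functional assay on the whole organism with Rattus norvegicus as the target (on this read-out higher numbers stand for an effect only at larger amounts of compound and lower numbers for an effect already at smaller amounts), compound 1 `COc1cc(N)c(Cl)cc1C(=O)NCCN(C)CC1CCCCC1` gives 3 mg/kg and compound 2 `COc1cc(N)c(Cl)cc1C(=O)NCCN(C)Cc1ccccc1C` gives 2 mg/kg. Compound 2 therefore stands level with compound 1, since the measured change is a 1.5-fold lower number from compound 1 to compound 2 (0.18 log units; within the scatter). Compound 3 `COc1cc(N)c(Cl)cc1C(=O)NCCN(C)Cc1ccccc1C(F)(F)F` carries trifluoromethyl in place of methyl on an aromatic carbon, ortho to a large group (trifluoromethyl in place of methyl on an aromatic carbon). Going by the values given here, the step from cyclohexyl to 2-methylphenyl is the only measured guide, and it stayed within the scatter, so no shift beyond the scatter is expected in this assay. The expected change is no change at the digits printed from compound 2 to compound 3 (within the scatter). Compound 3 is estimated at 2 mg/kg, with an expected range from 0.7 mg/kg to 6 mg/kg.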

Compound 3, dose for half-maximal effect: 30 mg/kg
For compound 3 the middle estimate is 15-fold (1.18 log units) below the measured one; the measured number lies above the stated range.
By their numbers in this assay, from the lowest: compounds 2 and 1 (each within the scatter of the next); then compound 3.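

In this assay, trifluoromethyl in place of methyl on this aromatic carbon, ortho to a large group, gives a 15-fold higher number from compound 2 to compound 3 (1.18 log units; beyond the scatter). The number at this one carbon therefore responds strongly to which group sits there, something the earlier step, 2-methylphenyl in place of cyclohexyl, did not reveal, as it stayed within the scatter. No measurement shown here accounts for the size of this jump. From the compounds shown here alone, whether a chlorine atom, a methoxy group or plain hydrogen on this same carbon would read like methyl or like trifluoromethyl remains open.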